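The compounds below may be only part of what the source reports. "The series", "measured", "known", "first", "only" and "open" are said of these compounds alone.

Compound 1 `COc1ccc(S(=O)(=O)Oc2ccccc2NC(=O)Nc2ccccc2)cc1`: > 10000 nM
Compound 2 `COc1ccc(S(=O)(=O)Oc2ccccc2NC(=O)c2ccc(F)cc2)cc1`: 550 nM

Going by the values given here, in a functional assay on NCI-H460 cells (Homo sapiens) for antiproliferative activity (a higher number here means a weaker inhibitor, a lower number a stronger inhibitor), compound 2 gives 550 nM, the only actual number so far. Compound 1 reads > 10000 nM, which is a limit of the assay and not a number.

Among the compounds with values here, the one measured step is an at least 18-fold lower number from compound 1 to compound 2 (1.25 log units; beyond the scatter). There, 4-fluorophenyl replaced anilino on a carbonyl carbon, the same place that changes next. Compound 3 `COc1ccc(S(=O)(=O)Oc2ccccc2NC(=O)c2ccnc3ccccc23)cc1` carries quinolin-4-yl in place of 4-fluorophenyl on a carbonyl carbon.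

The step of an at least 18-fold lower number from compound 1 to compound 2 (1.25 log units; beyond the scatter) bears on this change only indirectly. It shows that the group at this place can move the reading in this assay by a large amount, but it involves a different exchange and gives no direction for this one. A moderate step is therefore expected, with a slight lean towards a higher number and a wide margin on both sides.

The estimated step is a 1.5-fold higher number from compound 2 to compound 3 (0.16 log units; within the scatter). For compound 3 the expected value is 800 nM, with an estimated range from 120 nM to 5500 nM.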

Compound 3, half-maximal inhibitory concentration: > 10000 nM
Compound 3: no number, only a limit; the forecaster's own chance of this, stated with the estimate: 12%; at least 12-fold (1.09 log units) between middle value and limit.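

Putting quinolin-4-yl in place of 4-fluorophenyl on the carbonyl carbon gives, in this assay, an at least 18-fold higher number from compound 2 to compound 3 (1.25 log units; beyond the scatter), so a second exchange at this place also moves the reading by a large amount, this time away from the one number shown. Compound 3 reads > 10000 nM, which is a limit of the assay and not a number. Compound 1 and compound 3 both stop at a limit, so the step between them cannot be read, and 4-fluorophenyl remains the only group on this carbonyl carbon that gives a number: the limit of > 10000 nM in this assay, at which 2 of the 3 values shown sit.

From the compounds shown here alone, how far compound 3 lies past its limit stays open, and so does how much of the reading of compound 2 depends on the fluorine, which a plain phenyl group on the same carbonyl carbon would address. The compounds shown also do not separate the ring nitrogen of quinolin-4-yl from its second ring, a question that pyridin-4-yl and naphthalen-1-yl at this place would take apart.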